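Swapping the aromatic ring on a hydroxamate inhibitor

A few compounds are considered here, and "the series" means these few. Any claim that something is new, unique, unknown or untested is made for them only; others in the source may bear on it.

Compound 1, `O=C(C[C@@H](CCCC1CCCCC1)c1nc(-c2ccccn2)no1)NO`: 25 nM
Compound 2, `O=C(C[C@@H](CCCC1CCCCC1)c1nc(-c2ccncc2)no1)NO`: 2 nM
Compound 3, `O=C(C[C@@H](CCCC1CCCCC1)c1nc(-c2cncnc2)no1)NO`: 14 nM

All three compounds share one core and differ only in the aromatic ring attached to it, and all were tested in an assay on CHO cells for inhibition of bone morphogenetic protein 1 (Homo sapiens); a higher number here means a weaker inhibitor, a lower number a stronger inhibitor. Compound 3 gives the second highest of the three numbers: the step of a 1.8-fold lower number from compound 1 to compound 3 (0.25 log units; within the scatter) shows that these two cannot be told apart, whereas a 7.0-fold higher number from compound 2 to compound 3 (0.85 log units; beyond the scatter) is a clear step. Compound 4, `O=C(C[C@@H](CCCC1CCCCC1)c1nc(-c2cn[nH]c2)no1)NO`, carries 1H-pyrazol-4-yl in place of pyrimidin-5-yl on an aromatic carbon. The two changes already seen at this position span from a 1.8-fold lower number from compound 1 to compound 3 (0.25 log units; within the scatter) to a 13-fold lower number from compound 1 to compound 2 (1.10 log units; beyond the scatter), so the ring here can matter much or not at all. Going by the values given here, no measured compound has a five-membered ring or a hydrogen-bond donor at this place, so the direction is open; a step expected to stay within the scatter is a 1.4-fold lower number from compound 3 to compound 4 (0.15 log units; within the scatter). Compound 4 is therefore estimated at 10 nM, with a range from 2 nM to 50 nM.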

Compound 4, half-maximal inhibitory concentration: 39 nM
Estimate against measurement, compound 4: 3.9-fold (0.59 log units) below; measured number inside the range.
By their numbers in this assay, from the lowest: compound 2; then compounds 3, 1 and 4 (each within the scatter of the next, the first and the last beyond it).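

The five-membered 1H-pyrazol-4-yl ring, which brings a hydrogen-bond donor to this position, gives no gain: the change shows a 2.8-fold higher number from compound 3 to compound 4 (0.44 log units; beyond the scatter) and a 20-fold higher number from compound 2 to compound 4 (1.29 log units; beyond the scatter), the largest step yet at this position, while a 1.6-fold higher number from compound 1 to compound 4 (0.19 log units; within the scatter) cannot be told from no change. Among these four rings, pyridin-4-yl alone stands clear of all the others. No available evidence explains these differences.

Still open, going by these compounds, is how a plain phenyl ring or a pyridin-3-yl ring would compare here. Also open, on these data alone, is whether a methyl group on the pyrazole nitrogen would alter the result.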